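A few compounds are considered here, and "the series" means these few. Any claim that something is new, unique, unknown or untested is made for them only; others in the source may bear on it.

In an ADME assay on Vero cells (Chlorocebus sabaeus) for cytotoxicity, read by MTT assay, with a stated time of 72 h (a lower number here means that less compound is tolerated, a higher number that more compound is tolerated), compound 1 `COC(=O)c1cc(-c2cccc(NC(=O)c3ccc(/C=C/C(=O)c4cccc(Cl)c4)cc3)c2)on1` is known only through a limit of the assay, not a number: > 2.5 ug/mL. Compound 2 `CCOc1ccc(C(=O)/C=C/c2ccc(C(=O)Nc3cccc(-c4cc(C(=O)OC)no4)c3)cc2)cc1` also stands at a limit in this assay, > 40 ug/mL. Compound 3 `COC(=O)c1cc(-c2cccc(NC(=O)c3ccc(/C=C/C(=O)c4cc(F)ccc4F)cc3)c2)on1` likewise reaches a limit, > 40 ug/mL. Within the data shown here, these limits leave the three measured steps, a step that the two limits leave unreadable from compound 1 to compound 2, a step that the two limits leave unreadable from compound 1 to compound 3 and a step that the two limits leave unreadable from compound 2 to compound 3, without a readable size; the only evidence is the limit of > 2.5 ug/mL in this assay, at which 1 of the 3 values shown sits, and (the limit of > 40 ug/mL in this assay, at which 2 of the 3 values shown sit). Compound 4 `COC(=O)c1cc(-c2cccc(NC(=O)c3ccc(/C=C/C(=O)c4ccc(CC(C)C)cc4)cc3)c2)on1` differs from compound 1 by 4-isobutylphenyl in place of 3-chlorophenyl on a carbonyl carbon. With no readable step from any partner in this assay, neither direction nor size can be expected with confidence, and a further limit is the most likely outcome. Compound 4 is therefore estimated at 40 ug/mL, between 10 ug/mL and 100 ug/mL, which would mean an expected step that the limit leaves unreadable from compound 1 to compound 4.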

Compound 4, half-maximal cytotoxic concentration: > 10 ug/mL
Compound 4: a limit, no number (the forecaster's own chance of this, stated with the estimate: 70%); the middle value is on the limit's open side.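

In this assay, compound 4 gives only a limit, > 10 ug/mL, so its steps from compound 1, compound 2 and compound 3 cannot be read. The compounds shown leave open whether changing the group on the carbonyl carbon alters cytotoxicity at all.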